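The source may report more compounds than this note shows. Statements on the series, on what has been measured and on what is new or still open speak of the compounds shown alone.

In a functional assay on MDA-MB-231 cells (Homo sapiens) for cytotoxicity, read by MTT assay, with a stated time of 24 h (a higher number here means a weaker inhibitor, a lower number a stronger inhibitor), compound 1 (`CCCCCCCC/C=C\CCCCCCCC(=O)Nc1nnc(S[C@@H]2O[C@H](COC(C)=O)[C@H](OC(C)=O)[C@H](OC(C)=O)[C@H]2OC(C)=O)s1`) gives 23600 nM. That number lies within the scatter of compound 2 (`CCCCCCCCCCCCCC(=O)Nc1nnc(S[C@@H]2O[C@H](CO)[C@H](O)[C@H](O)[C@H]2O)s1`) at 33300 nM, while compound 3 (`CCCCCCCC/C=C\CCCCCCCCCCCC(=O)Nc1nnc(S[C@@H]2O[C@H](CO)[C@H](O)[C@H](O)[C@H]2O)s1`) reads higher at 70400 nM, beyond the scatter. Compound 4 (`CCCCCCCC(=O)Nc1nnc(S[C@@H]2O[C@H](COC(C)=O)[C@H](OC(C)=O)[C@H](OC(C)=O)[C@H]2OC(C)=O)s1`) departs from compound 1 by one change: hydrogen in place of dec-1-en-1-yl on a saturated chain carbon, seven bonds along the chain from a carbonyl carbon. Going by the values given here, only one measured step bears on this, a 2.1-fold higher number from compound 2 to compound 3 (0.33 log units; beyond the scatter), a modest rise on adding to the chain. That step comes from a pair that also differs from compound 1 elsewhere on the shared core, so it is only a loose guide. Removing chain here suggests a small fall in this assay, and the expected change is a 1.5-fold lower number from compound 1 to compound 4 (0.17 log units; within the scatter), possibly no more than scatter. For compound 4 the estimated value is 16000 nM, with an expected range of 6000 nM to 45000 nM.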

Compound 4, half-maximal inhibitory concentration: 18900 nM
Beside the measured number, compound 4's estimate is 1.2-fold (0.07 log units) below it; the measured number falls inside the stated range.
By their numbers in this assay, from the lowest: compounds 4, 1 and 2 (each within the scatter of the next); then compound 3.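

Putting hydrogen in place of dec-1-en-1-yl, seven bonds along the chain from a carbonyl carbon, gives a 1.2-fold lower number from compound 1 to compound 4 (0.10 log units; within the scatter) in this assay and so leaves the number within the scatter. Going by these compounds alone, this large cut to the chain on the core of compound 1 therefore reads differently from the only earlier chain step, a 2.1-fold higher number from compound 2 to compound 3 (0.33 log units; beyond the scatter), which lay beyond the scatter but was taken on a differently substituted core. As far as these compounds go, whether a still shorter chain, or an amine or a carboxylic acid in place of the chain, would move the number beyond the scatter stays open. Nothing available explains this result.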